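Furan to thiophene on a fused dihydropyrimidine ester

This account rests on a few compounds, and the source may have more. Where it says the series, first, only, none or still open, it means among the compounds named here.

Measured compounds: compound 1 `CCOC(=O)C1=C(C)Nc2ncnn2C1c1ccoc1` gives 602 nM; compound 2 `CC1=C(C(=O)OC(C)C)C(c2ccoc2)n2ncnc2N1` gives 351 nM, both in an assay on HEK293 cells for displacement of a labelled ligand from adenosine receptor A2b (Homo sapiens), with a stated time of 30 min; a lower number here means a stronger inhibitor, a higher number a weaker inhibitor.

Compound 2 stands alongside compound 1 on the two numbers shown: the single measured step, a 1.7-fold lower number from compound 1 to compound 2 (0.23 log units; within the scatter), concerns only the ester alkyl group, and the two values cannot be told apart within the scatter. Compound 3 `CC1=C(C(=O)OC(C)C)C(c2ccsc2)n2ncnc2N1` differs from compound 2 by thiophen-3-yl in place of furan-3-yl on a saturated ring carbon. No measured step touches this part of the shared core, so nothing among the numbers shown speaks for a shift in either direction, and a step within the scatter is the expectation for this assay. Compound 3 is therefore estimated at 320 nM, between 120 nM and 850 nM, which corresponds to an expected step of a 1.1-fold lower number from compound 2 to compound 3 (0.04 log units; within the scatter).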

Compound 3, inhibition constant: 817 nM
Estimate against measurement, compound 3: 2.6-fold (0.41 log units) below; the measured number falls inside the stated range.
By their numbers in this assay, from the lowest: compounds 2, 1 and 3 (each within the scatter of the next, the first and the last beyond it).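

In this assay, within the data shown here, the group on the saturated ring carbon proves to count for more than the earlier ester change did: this exchange gives a modest step beyond the scatter (a 2.3-fold higher number from compound 2 to compound 3 (0.37 log units; beyond the scatter)), whereas the only earlier step, in the ester alkyl group, stayed within it. Furan-3-yl and thiophen-3-y l have the same heavy-atom count, ring size and hydrogen-bond counts, so the difference in the number goes with one ring atom, sulfur in place of oxygen, and it favours furan-3-yl on this isopropyl ester. Nothing available accounts for the shift.

On these data alone, whether the same step would appear with the ethyl ester of compound 1 stays open. So does what a phenyl ring, a pyridine ring or a saturated cyclopentyl group would give on this ring carbon.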